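The source may hold more compounds than are shown below. What is called first, only, known or untested is meant among the compounds shown, and "the series" means these compounds.

Series notes. In an ADME assay on BaF3 cells (Mus musculus) for antiproliferative activity, read by CellTiter-Glo and CCK-8 assay, with a stated time of 72 h (on this read-out higher numbers stand for weaker inhibition of growth and lower numbers for stronger inhibition of growth), compound 1 `Cc1ccc(NC(=O)c2cccc(C(F)(F)F)c2)cc1N1Cc2cnc(Nc3ccc(C)c(C(F)(F)F)c3)nc2N(C)C1=O` reaches only the assay limit, > 10000 nM. Compound 2 `Cc1ccc(Nc2ncc3c(n2)N(C)C(=O)N(c2cc(NC(=O)c4cc(C(C)(C)C)cc(C(C)(C)C)c4)ccc2C)C3)cc1N` likewise returns the limit > 10000 nM. Compound 3 `Cc1cccc(C(=O)Nc2ccc(C)c(N3Cc4cnc(Nc5ccc(C)c(N)c5)nc4N(C)C3=O)c2)c1` also returns the limit > 10000 nM. Going by the values given here, no measured pair differing in a single place exists, so no step size is known; the three values sit together as the limit of > 10000 nM in this assay, at which 3 of the 3 values shown sit. Compound 1 therefore stands at the same limit as the other two, and no order among the three can be stated. Compound 4 `Cc1ccc(NC(=O)c2cccc(C(F)(F)F)c2)cc1N1Cc2cnc(O[C@H]3CCNC3)nc2N(C)C1=O` carries (pyrrolidin-3-yl)oxy in place of (4-methyl-3-(trifluoromethyl)phenyl)amino on an aromatic carbon, in words: (pyrrolidin-3-yl)oxy in place of (4-methyl-3-(trifluoromethyl)phenyl)amino on an aromatic carbon. Lacking any numbered analogue value, the step expected in this assay is an at least 1.1-fold lower number from compound 1 to compound 4 (0.04 log units; that floor lies within the scatter), within the scatter, direction unknown. The estimate for compound 4 in this assay is 9000 nM, range 1500 nM to 40000 nM, a limit remaining the likelier outcome.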

Compound 4, concentration for 50% growth inhibition: > 10000 nM
Compound 4 ended at the assay's limit; the forecaster's own chance of this, stated with the estimate: 60%; middle value at least 1.1-fold (0.04 log units) from the limit.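

No step can be read between compound 1 and compound 4 in this assay, since both values are limits: the limit of > 10000 nM in this assay, at which 4 of the 4 values shown sit. The compounds shown leave open which change, if any, would bring a value inside the assay's range.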